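The compounds below may be only part of what the source reports. "The series", "measured", "known", "first", "only" and "open" are said of these compounds alone.

Compound 1, `CCOC(=O)c1c(C)noc1OCC(=O)[C@H](CC(=O)O)NC(=O)[C@@H](NC(=O)COc1cccc2ccccc12)C(C)C`, and compound 2, `Cc1cc(OCC(=O)[C@H](CC(=O)O)NC(=O)[C@@H](NC(=O)COc2cccc3ccccc23)C(C)C)nc(C)n1`, share a core and differ only where 2,6-dimethylpyrimidin-4-yl stands in place of 4-(ethoxycarbonyl)-3-methyl-1,2-oxazol-5-yl on an oxygen on a saturated carbon. In a functional assay on Jurkat cells (Homo sapiens) for inhibition (on this read-out higher numbers stand for weaker inhibition and lower numbers for stronger inhibition), compound 1 reaches only a limit of > 200000 nM. In this assay compound 2 likewise reaches only a limit of > 200000 nM. The step that the two limits leave unreadable from compound 1 to compound 2 is therefore not readable, since the limit of > 200000 nM in this assay, at which 2 of the 2 values shown sit, is all that either compound shows. Compound 2 thus stands at the limit and nowhere more precisely.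

Compound 3, `CC(C)[C@H](NC(=O)COc1cccc2ccccc12)C(=O)N[C@@H](CC(=O)O)C(=O)CSc1nccc(C(F)(F)F)n1`, is not yet measured. It differs from compound 2 by (4-(trifluoromethyl)pyrimidin-2-yl)sulfanyl in place of (2,6-dimethylpyrimidin-4-yl)oxy on a saturated chain carbon bound to a carbonyl carbon. Going by the values given here, no measured step bears on this change: the one step that exists is unreadable, and both measured values are limits. With compound 2 at > 200000 nM, compound 3 is expected to stay weak, and a readable number is thought unlikely. This expectation corresponds to a step of a number no higher from compound 2 to compound 3 (the limit leaves the size open). Compound 3 is estimated at 200000 nM in this assay, within a range from 20000 nM to 2000000 nM.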

Compound 3, half-maximal inhibitory concentration: > 200000 nM
Compound 3 was reported as a limit (the forecaster's own chance of this, stated with the estimate: 70%); the middle value lies on the limit itself.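

In this assay compound 3 gives > 200000 nM, which is a limit. Going by these compounds alone, no step among compound 1, compound 2 and compound 3 can therefore be read. The compounds shown leave open how the groups at this one place of change compare in this assay, as all three stop at the same limit: the limit of > 200000 nM in this assay, at which 3 of the 3 values shown sit.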